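A few compounds are considered here, and "the series" means these few. Any claim that something is new, unique, unknown or untested is made for them only; others in the source may bear on it.

Measured compounds and values in a functional assay on HEK293 cells for negative allosteric modulation of metabotropic glutamate receptor 5 (Rattus norvegicus), read by FLIPR and calcium flux, with a stated time of 170 s; a lower number here means a stronger inhibitor, a higher number a weaker inhibitor:

Compound 1 `c1ccc(-c2cc3n(n2)CCCC3)nc1` — compound 1 gives 1290 nM
Compound 2 `Cc1ccc(-c2cc3n(n2)CCCC3)nc1` — compound 2 gives 3000 nM
Compound 3 `O=C(Cc1ccccn1)c1cc2n(n1)CCCC2` — compound 3 gives 390 nM

Compound 3 carries the lowest number of the three in this assay. Compound 1 is nearest to it, and the gap from compound 3 to compound 1 is beyond the scatter; compound 2 is furthest, and that gap is also beyond the scatter. Compound 3 differs from compound 1 in the link between the shared core and the pyridine, a carbonyl-bearing two-atom link in place of a direct bond.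

Compound 4 `N#Cc1ccc(CC(=O)c2cc3n(n2)CCCC3)nc1` is not yet measured. It differs from compound 3 by cyano in place of hydrogen on an aromatic carbon.

For the measured compounds named here, one measured step bears on this: a 2.3-fold higher number from compound 1 to compound 2 (0.37 log units; beyond the scatter). That step also puts a small group on an aromatic carbon of the pyridine, though a methyl rather than a cyano and on a compound without the carbonyl link. It gives a modest weakening. Going by the values given here, no measured pair shows a cyano entering anywhere, so the direction for compound 4 rests on a single indirect comparison.

Compound 4 is therefore expected to sit near compound 3 or somewhat weaker, with the step of a 1.3-fold higher number from compound 3 to compound 4 (0.11 log units; within the scatter) estimated as small and the number for compound 4 estimated at 500 nM, within a range of 160 nM to 1600 nM.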

Compound 4, half-maximal inhibitory concentration: 53 nM
For compound 4 the middle estimate is 9.4-fold (0.97 log units) above the measured one; measured number below the stated range.
By their numbers in this assay, from the lowest: compound 4; then compound 3; then compound 1; then compound 2.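

In this assay, the aromatic carbon para to a large group, two atoms from the ring nitrogen, proves able to give a clear gain, with cyano in place of hydrogen giving a 7.4-fold lower number from compound 3 to compound 4 (0.87 log units; beyond the scatter). The only earlier substitution at this place, a methyl on the directly linked pyridine, went the other way, a 2.3-fold higher number from compound 1 to compound 2 (0.37 log units; beyond the scatter), so a group at this carbon does not move the number in a single direction across the compounds shown, although those two steps differ in both the entering group and the link. Nothing available accounts for the lower number with cyano.

On these data alone, it remains open whether the gain belongs to the cyano alone or depends on the carbonyl-bearing link, a question that a cyano on the directly linked compound 1 and a methyl on the linked compound 3 would separate. Also open, as far as these compounds go, is how far the gain extends to other groups on this carbon, such as a chlorine, a methoxy or a primary carboxamide.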